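Trifluoromethyl moved onto the benzyl group: compound 4

The source may hold more compounds than are shown below. What is called first, only, known or untested is meant among the compounds shown, and "the series" means these compounds.

Compound 3 `CCc1nc(Cl)c2n1CCN([C@@H](C(=O)NC)c1ccccc1)[C@H]2CCc1ccc(F)c(F)c1F` gives 5 nM in a functional assay on CHO cells for antagonist activity at Orexin receptor type 2 (Homo sapiens), read by FLIPR and calcium flux (a lower number here means a stronger inhibitor, a higher number a weaker inhibitor), the second highest of three numbers. Compound 1 `CCc1nc(Cl)c2n1CCN([C@@H](C(=O)NC)c1ccccc1)[C@H]2COc1cccc(C(F)(F)F)c1`, carrying 3-(trifluoromethyl)phenoxy, gives 4 nM in this assay, and compound 2 `CCc1nc(Cl)c2n1CCN([C@@H](C(=O)NC)c1ccccc1)[C@H]2CCc1ccc(C(F)(F)F)c(F)c1F` gives 14 nM. The step of a 1.3-fold higher number from compound 1 to compound 3 (0.10 log units; within the scatter) stays within the scatter; the step of a 2.8-fold lower number from compound 2 to compound 3 (0.45 log units; beyond the scatter) is modest but beyond it. Compound 4 `CCc1nc(Cl)c2n1CCN([C@@H](C(=O)NC)c1ccccc1)[C@H]2CCc1cccc(C(F)(F)F)c1F` differs from compound 3 by 2-fluoro-3-(trifluoromethyl)phenyl in place of 2,3,4-trifluorophenyl on a saturated chain carbon, two bonds along the chain from a saturated ring carbon. Both steps bear on this change: compound 1 shows a trifluoromethyl on the aryl ring is tolerated, while compound 2 shows that trifluoromethyl replacing fluoro on the benzyl ring cost a modest amount. A step of about a 1.4-fold higher number from compound 3 to compound 4 (0.15 log units; within the scatter) in this assay is therefore expected, a small weakening. Compound 4 is estimated at 7 nM, with a range from 3 nM to 18 nM.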

Compound 4, half-maximal inhibitory concentration: 9 nM
Beside the measured number, compound 4's estimate is 1.3-fold (0.11 log units) below it, within the range that was stated.
By their numbers in this assay, from the lowest: compounds 1, 3, 4 and 2 (each within the scatter of the next, the first and the last beyond it).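

Read in this assay at this place, 2-fluoro-3-(trifluoromethyl)phenyl is not separated from 2,3,4-trifluorophenyl, with a 1.8-fold higher number from compound 3 to compound 4 (0.26 log units; within the scatter) as the step, or from 2,3-difluoro-4-(trifluoromethyl)phenyl, with a 1.6-fold lower number from compound 2 to compound 4 (0.19 log units; within the scatter) as the step. Only the change from 3-(trifluoromethyl)phenoxy to 2-fluoro-3-(trifluoromethyl)benzyl, with a 2.3-fold higher number from compound 1 to compound 4 (0.35 log units; beyond the scatter) as a modest step, lies beyond the scatter. No supporting measurement bears on the reason for these steps.

Still open, on these data alone, is how an amine or a carboxylic acid on this aryl ring would behave. As far as these compounds go, a longer chain to the ring also remains open.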